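The source may hold more compounds than are shown below. What is called first, only, known or untested is meant among the compounds shown, and "the series" means these compounds.

Three related compounds have been read in a functional assay on HepG2 cells (Homo sapiens) for cytotoxicity, read by MTT assay, with a stated time of 72 h; on this read-out higher numbers stand for weaker inhibition and lower numbers for stronger inhibition: compound 1 (`CNC(=O)c1cc(Oc2ccc(C3=NNC(c4ccccc4)C3)cc2)ccn1`), compound 2 (`CNC(=O)c1cc(Oc2ccc(C3=NNC(c4ccc(OC)c(OC)c4OC)C3)cc2)ccn1`) and compound 3 (`CNC(=O)c1cc(Oc2ccc(C3CC(c4ccc([N+](=O)[O-])cc4)=NN3)cc2)ccn1`). Compound 1 gives 1500 nM and compound 2 gives 15700 nM. Compound 3 gives 28900 nM, which lies within the scatter of compound 2 and well beyond the scatter of compound 1.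

Compound 4 (`CNC(=O)c1cc(Oc2ccc(C3CC(c4ccc(Br)cc4)=NN3)cc2)ccn1`) has not yet been measured. It departs from compound 3 at one place: bromo in place of nitro on an aromatic carbon. Seen as whole groups, 4-nitrophenyl gives way to 4-bromophenyl.

Within the data shown here, no two measured compounds differ in only one place, so the data give no direct measure of this change. Among the measured compounds shown here, the gap between compound 3 at 28900 nM and compound 1 at 1500 nM shows only that much lower numbers occur in this small set. A moderate step toward a lower number, meaning stronger inhibition, is therefore expected in this assay, although it may not clear the scatter by much. The expected size is an estimated step of a 3.2-fold lower number from compound 3 to compound 4 (0.51 log units; beyond the scatter). For compound 4 the estimated value is 9000 nM, with an expected range from 2500 nM to 30000 nM.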

Compound 4, half-maximal inhibitory concentration: 16900 nM
The estimate for compound 4 lay 1.9-fold (0.27 log units) below the measured number; low and high end bracket the measured number.
By their numbers in this assay, from the lowest: compound 1; then compounds 2, 4 and 3 (each within the scatter of the next).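

Among these compounds, in the first direct comparison at this place on the ring, bromo in place of nitro on an aromatic carbon gives a 1.7-fold lower number from compound 3 to compound 4 (0.23 log units; within the scatter) in this assay. The two groups therefore cannot be told apart in this assay's read-out, even though the change takes away the hydrogen-bond acceptors of the nitro group and leaves a single bromine atom with none. No measured property of either group is available to account for this result.

The compounds shown leave open whether any group at this place, para to a large group, can move the number beyond the scatter, as 4-nitrophenyl and 4-bromophenyl are the only two forms seen here in this arrangement of the core. An amine, a carboxylic acid, a methoxy group or plain hydrogen at the same aromatic carbon would test this, and would show whether the position responds at all or whether the read-out stays in the same range whatever group sits there.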